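The source may hold more compounds than are shown below. What is called first, only, known or untested is meant among the compounds shown, and "the series" means these compounds.

Measured in a functional assay on KYSE-450 cells (Homo sapiens) for inhibition, read by CCK-8 assay, with a stated time of 48 h; a higher number here means a weaker inhibitor, a lower number a stronger inhibitor:
- compound 1 `COc1ccc(CN(C(=O)CSC(=S)N2CCN(C)CC2)c2cc(OC)c(OC)c(OC)c2)cc1`: 1250 nM
- compound 2 `COc1ccc(CN(C(=O)CSC(=S)N2CCN(C(C)=O)CC2)c2cc(OC)c(OC)c(OC)c2)cc1`: 370 nM
- compound 3 `COc1ccc(CN(C(=O)CSC(=S)N2CCc3cc(Br)ccc32)c2cc(OC)c(OC)c(OC)c2)cc1`: > 20000 nM (a limit of the assay, not a number)

Compound 2 has the lower of the two actual numbers, which makes it the strongest inhibitor of the three. Compound 4 `CCN1CCN(CC(=O)N(Cc2ccc(OC)cc2)c2cc(OC)c(OC)c(OC)c2)CC1` differs from it as follows: a group of 8 heavy atoms (6 carbon, 2 nitrogen; one six-membered non-aromatic ring with 2 hetero atoms) in place of a group of 12 heavy atoms (7 carbon, 2 nitrogen, 1 oxygen, 2 sulfur; one six-membered non-aromatic ring with 2 hetero atoms), on a saturated chain carbon bound to a carbonyl carbon. The entering group is 4-ethylpiperazin-1-yl.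

Within the data shown here, two measured steps bear on this. Acetyl in place of methyl on the ring nitrogen gave a 3.4-fold lower number from compound 1 to compound 2 (0.53 log units; beyond the scatter), so the methyl compound was the weaker. Replacing the whole ring group gave an at least 54-fold higher number from compound 2 to compound 3 (1.73 log units; beyond the scatter), so changes in this region can matter greatly. Among the measured compounds shown here, no measured compound lacks the thiocarbonyl.

A modest to large weakening is therefore expected in this assay, namely a 6.8-fold higher number from compound 2 to compound 4 (0.83 log units; beyond the scatter). For compound 4 the estimated value is 2500 nM, with an expected range from 600 nM to 12000 nM.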

Compound 4, half-maximal inhibitory concentration: 16100 nM
The estimate for compound 4 lay 6.4-fold (0.81 log units) below the measured number; measured number above the stated range.
By their numbers in this assay, from the lowest: compound 2; then compound 1; then compound 4. At a limit, above all of these: compound 3.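

In this assay, putting 4-ethylpiperazin-1-yl on the saturated chain carbon gave a 44-fold higher number from compound 2 to compound 4 (1.64 log units; beyond the scatter), and also a 13-fold higher number from compound 1 to compound 4 (1.11 log units; beyond the scatter). Keeping a six-membered non-aromatic ring with 2 hetero atoms therefore does not keep the activity, so the sulfur-bearing part that leaves matters here. Compound 3 remains a limit of the assay: the limit of > 20000 nM in this assay, at which 1 of the 4 values shown sits.

Still open, from the compounds shown here alone, is whether the loss follows the thiocarbonyl and its sulfur atoms or the ethyl on the ring nitrogen. A 4-acetylpiperazin-1-yl group on the same chain carbon, or an ethyl on the ring nitrogen with the thiocarbonyl kept, would separate the two.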